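This account rests on a few compounds, and the source may have more. Where it says the series, first, only, none or still open, it means among the compounds named here.

Among the measured compounds shown here, in a functional assay on MCF7 cells (Homo sapiens) for cytotoxicity, read by MTT assay, with a stated time of 24 h (on this read-out higher numbers stand for weaker inhibition and lower numbers for stronger inhibition), compound 1 `Nc1cccn2cc(Cc3ccccc3)c(=O)nc12` gives 105000 nM and compound 2 `Nc1cccn2cc(Cc3ccc(F)cc3)c(=O)nc12` gives 135000 nM, so compound 2 stands within the scatter of its only numerical neighbour. The step of a 1.3-fold higher number from compound 1 to compound 2 (0.11 log units; within the scatter) concerns only the fluoro group, which compound 4 `O=c1nc2ccccn2cc1Cc1ccc(F)cc1` keeps, so it gives no size for the new change. That change is hydrogen in place of amino on an aromatic carbon. Compound 3 `O=c1nc2ccc(Br)cn2cc1Cc1ccccc1`, which also has no amino group but carries bromo and no fluoro, reports only a limit, > 1000000 nM. For the measured compounds named here, with compound 3 and its > 1000000 nM as the only guide, weaker inhibition is expected, and the estimated step is a 3.0-fold higher number from compound 2 to compound 4 (0.47 log units; beyond the scatter). Compound 4 is expected at 400000 nM, within an estimated range of 130000 nM to 1000000 nM.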

Compound 4, half-maximal inhibitory concentration: 200000 nM
Compound 4: middle estimate off by 2.0-fold (0.30 log units), on the high side; measured number inside the range.
By their numbers in this assay, from the lowest: compounds 1, 2 and 4 (each within the scatter of the next). At a limit, above all of these: compound 3.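

In this assay, hydrogen in place of amino on an aromatic carbon gives a 1.5-fold higher number from compound 2 to compound 4 (0.17 log units; within the scatter). Among the compounds shown here, this is the first direct reading of this change at this position, and the amino group makes no difference here that stands beyond the scatter. Compound 3 differs from compound 4 in more than one place, so it gives no such reading, and its value is only a limit: the limit of > 1000000 nM in this assay, at which 1 of the 4 values shown sits.

Going by these compounds, whether a methylamine, a hydroxyl or a carboxylic acid at this position would read the same stays open. So does the effect of bromo alone on the shared core.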